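From compound 2 to compound 3: replacing 1-acetylpiperidin-4-yl

The source may hold more compounds than are shown below. What is called first, only, known or untested is meant among the compounds shown, and "the series" means these compounds.

Within the data shown here, compound 2 `COc1cccc(NC(=O)c2nnn(CC3CCN(C(C)=O)CC3)c2N)c1` stands level with its only measured neighbour, compound 1 `COc1cccc(NC(=O)c2nnn(Cc3ccncc3)c2N)c1`. In an ADME assay on microsomes from liver (Mus musculus, strain CD1) for metabolic stability, read by HPLC, using NADPH, with a stated time of 30 min (a higher number here means faster removal of the compound, a lower number slower removal), compound 1 gives 0.7 mL.min-1.g-1 and compound 2 gives 0.7 mL.min-1.g-1. Among the measured compounds shown here, the one measured step, no change at the digits printed from compound 1 to compound 2 (within the scatter), put 1-acetylpiperidin-4-yl in place of pyridin-4-yl. Compound 3 `COc1cccc(NC(=O)c2nnn(Cc3ccc([S+](C)[O-])cc3)c2N)c1` changes the same place, on a saturated chain carbon bound to an aromatic nitrogen: a group of 9 heavy atoms (7 carbon, 1 oxygen, 1 sulfur; one six-membered aromatic ring of carbon only) in place of a group of 9 heavy atoms (7 carbon, 1 nitrogen, 1 oxygen; one six-membered non-aromatic ring with 1 hetero atom), on a saturated chain carbon bound to an aromatic nitrogen. For the measured compounds named here, with no change at the digits printed from compound 1 to compound 2 (within the scatter) as the only guide, no step beyond the scatter is expected in this assay, though the entering group is untested. The expected step is a 1.4-fold higher number from compound 2 to compound 3 (0.15 log units; within the scatter). Compound 3 is estimated at 1 mL.min-1.g-1, with an expected range of 0.4 mL.min-1.g-1 to 2.5 mL.min-1.g-1.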

Compound 3, intrinsic clearance in microsomes: 0.5 mL.min-1.g-1
Compound 3: the middle estimate sits 2.0-fold (0.30 log units) above what was measured, within the range that was stated.
By their numbers in this assay, from the lowest: compounds 3, 1 and 2 (each within the scatter of the next).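

In this assay the place on a saturated chain carbon bound to an aromatic nitrogen now holds a third kind of group, with a six-membered aromatic ring of carbon only and a sulfur atom, and the steps stay within the scatter (a 1.4-fold lower number from compound 2 to compound 3 (0.15 log units; within the scatter)) and (a 1.4-fold lower number from compound 1 to compound 3 (0.15 log units; within the scatter)). Among compounds 1, 2 and 3, this place accepts an aromatic ring with or without a hetero atom and a non-aromatic ring without a step beyond the scatter. Nothing at hand explains this.

Still open, on these data alone, is whether a group without a ring, such as a longer alkyl chain, would read the same here. The same question stands for a group carrying a carboxylic acid or a free amine.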